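The compounds below may be only part of what the source reports. "The series", "measured", "known", "first", "only" and "open" are said of these compounds alone.

Compound 1 `O=C(CSc1nncnc1-c1ccccc1Cl)Nc1ccc(Cl)cc1Cl` is an amide carrying a 2,4-dichlorophenyl group on its nitrogen. In an ADME assay on MT4 cells (Homo sapiens) for cytotoxicity, read by MTT assay (a higher number here means that more compound is tolerated, a lower number that less compound is tolerated), compound 1 gives 51000 nM, the lowest of the three numbers measured: compound 2 `O=C(CSc1nncnc1-c1cccc2ccccc12)Nc1ccccc1` gives 154000 nM and compound 3 `O=C(CSc1nncnc1-c1cccc2ccccc12)Nc1ccc(Cl)cc1Cl` gives 254000 nM, and both of those gaps to compound 1 lie beyond the scatter. Compound 4 `O=C(CSc1nncnc1-c1ccccc1Cl)Nc1ccccc1F` differs from compound 1 by 2-fluorophenyl in place of 2,4-dichlorophenyl on an amide-type nitrogen. For the measured compounds named here, the only measured step at the amide-type nitrogen, a 1.6-fold higher number from compound 2 to compound 3 (0.22 log units; within the scatter), stayed within the scatter, so exchanging one aromatic ring for another there has so far moved the number little. For compound 4 the change is therefore expected to be small, a 1.3-fold lower number from compound 1 to compound 4 (0.11 log units; within the scatter), with a slight downward lean at most. Compound 4 is estimated at 40000 nM, between 15000 nM and 110000 nM.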

Compound 4, half-maximal cytotoxic concentration: 98000 nM
The estimate for compound 4 lay 2.5-fold (0.39 log units) below the measured number; the range from low to high includes it.
By their numbers in this assay, from the lowest: compounds 1, 4, 2 and 3 (each within the scatter of the next, the first and the last beyond it).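

In this assay, the step of a 1.9-fold higher number from compound 1 to compound 4 (0.28 log units; within the scatter) stays within the scatter even though two chlorines give way to one fluorine. This is a second swap of one substituted aromatic ring for another on the amide-type nitrogen that leaves the number little changed, now on the core of compound 1 rather than the different core of the earlier step. Nothing measured here accounts for this result. Still open, going by these compounds, is whether a non-aromatic group on this nitrogen, such as a longer alkyl chain or a chain ending in an amine or a carboxylic acid, would move the number beyond the scatter.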